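Ortho Isopropyl Aryl Triazole Urea Versus Meta Methyl Analogue

The compounds below may be only part of what the source reports. "The series", "measured", "known", "first", "only" and "open" are said of these compounds alone.

Measured compounds:
- compound 1, `COc1cccc(-n2cc(COc3cccc(NC(=O)Nc4ccc(Cl)c(C(F)(F)F)c4)c3)nn2)c1`: 1310 nM
- compound 2, `COc1ccc(-n2cc(COc3cccc(NC(=O)Nc4ccc(Cl)c(C(F)(F)F)c4)c3)nn2)cc1`: 4680 nM
- compound 3, `Cc1cccc(-n2cc(COc3cccc(NC(=O)Nc4ccc(Cl)c(C(F)(F)F)c4)c3)nn2)c1`: 7270 nM

In a functional assay on HepG2 cells (Homo sapiens) for inhibition, read by MTT assay, with a stated time of 72 h (a lower number here means a stronger inhibitor, a higher number a weaker inhibitor), compound 3 gives the highest of the three numbers. Its nearest neighbour is compound 2, a 1.6-fold higher number from compound 2 to compound 3 (0.19 log units; within the scatter), a gap within the scatter, so no order between these two can be read. Its furthest neighbour is compound 1, a 5.5-fold higher number from compound 1 to compound 3 (0.74 log units; beyond the scatter).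

Compound 4, `CC(C)c1ccccc1-n1cc(COc2cccc(NC(=O)Nc3ccc(Cl)c(C(F)(F)F)c3)c2)nn1`, differs from compound 3 in one place: 2-isopropylphenyl in place of 3-methylphenyl on an aromatic nitrogen. For the measured compounds named here, none of the measured steps changes this group in the same way. The step of a 3.6-fold higher number from compound 1 to compound 2 (0.55 log units; beyond the scatter) moves a substituent around the same aryl ring, and a 5.5-fold higher number from compound 1 to compound 3 (0.74 log units; beyond the scatter) swaps one substituent for another at a fixed position; both were modest, and a 1.6-fold higher number from compound 2 to compound 3 (0.19 log units; within the scatter) stayed within the scatter. Taken together they show that such aryl changes shift the number only modestly, with no measured example of a 2-isopropylphenyl to lean on.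

On that basis compound 4 is expected to land near compound 3, with a step of a 1.0-fold higher number from compound 3 to compound 4 (0.01 log units; within the scatter) that is not expected to exceed the scatter. The estimate for compound 4 in this assay is 7500 nM, within a range from 2500 nM to 22000 nM.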

Compound 4, half-maximal inhibitory concentration: 1900 nM
For compound 4 the middle estimate is 3.9-fold (0.60 log units) above the measured one, outside the stated range (below it).
By their numbers in this assay, from the lowest: compounds 1 and 4 (each within the scatter of the next); then compounds 2 and 3 (each within the scatter of the next).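

In this assay, 2-isopropylphenyl on the aromatic nitrogen gives a clear step from 3-methylphenyl, a 3.8-fold lower number from compound 3 to compound 4 (0.58 log units; beyond the scatter), and another from 4-methoxyphenyl, a 2.5-fold lower number from compound 2 to compound 4 (0.39 log units; beyond the scatter), so the aryl group at this position can move the number in the lower direction without any methoxy group. Until now the lowest number belonged to the 3-methoxyphenyl of compound 1, but compared with that group the new aryl group gives a 1.5-fold higher number from compound 1 to compound 4 (0.16 log units; within the scatter), so no order can be read and a ring of carbon only, with no hydrogen-bond acceptor, can match it, although compound 3, also carbon only, stays at the higher level with compound 2. Nothing available explains why this change acts as it does on these cells.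

Compound 4 differs from compound 3 in both the size of the alkyl group and its place on the aryl ring, so the compounds shown leave open which of the two accounts for the step. They also leave open how an amine, a carboxylic acid or a longer chain on this aryl ring would compare with the isopropyl group.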